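Bromo for chloro on the fused ring: compound 4

The source may hold more compounds than are shown below. What is called first, only, known or untested is meant among the compounds shown, and "the series" means these compounds.

Among the measured compounds shown here, the series so far holds three measured compounds. Compound 1 `COc1cc(Br)cc2c1OC(N)=C(C#N)C2CC(=O)c1ccccc1` gives 45.9% in an ADME assay on MCF-10A cells (Homo sapiens) for cytotoxicity, read by sulforhodamine B assay, with a stated time of 72 h, tested at 10 uM; on this read-out higher numbers stand for a stronger effect at the one concentration tested and lower numbers for a weaker effect. For the measured compounds named here, compound 2 `COc1cc(Br)cc2c1OC(N)=C(C#N)C2CC(=O)c1ccc(Cl)cc1` gives 36.8%, and the one measured step, a number 9.1 percentage points lower from compound 1 to compound 2 (within the scatter), lies within the scatter. Compound 3 `Cc1ccc(C(=O)CC2C(C#N)=C(N)Oc3ccc(Cl)cc32)cc1` gives 41.8%; it stands second highest of the three numbers, with compound 1 nearest and compound 2 furthest, both gaps within the scatter, so the three compounds are not separated on this read-out.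

Compound 4 `Cc1ccc(C(=O)CC2C(C#N)=C(N)Oc3ccc(Br)cc32)cc1` is not yet measured. It differs from compound 3 by bromo in place of chloro on an aromatic carbon. Going by the values given here, no measured step swaps one halogen for another on the fused ring: the only measured step is a chloro entering on the other aromatic ring, and compound 1 and compound 3 differ in two places at once, so they show only that a bromo-bearing and a chloro-bearing core give values within the scatter of each other. The step is therefore expected to be small, within the scatter, in no clear direction: a number 0.2 percentage points higher from compound 3 to compound 4 (within the scatter). For compound 4 the estimate is 42%, with a range from 30% to 54%.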

Compound 4, a percentage reported as activity, at one concentration (the size of the read-out at that concentration, not a potency): 133%
For compound 4 the middle estimate is 91 percentage points below the measured one; measured number above the stated range.
By their numbers in this assay, from the lowest: compounds 2, 3 and 1 (each within the scatter of the next); then compound 4.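

In this assay, bromo in place of chloro on the fused ring gives a large step, a number 91.2 percentage points higher from compound 3 to compound 4 (beyond the scatter), and it is beyond the scatter. Among the compounds shown here, the only other step that can be read, chloro in place of hydrogen on an aromatic carbon, stays within the scatter at a number 9.1 percentage points lower from compound 1 to compound 2 (within the scatter), so this single-atom halogen swap is the first change to separate two compounds on this read-out. Nothing measured here accounts for the gap between bromo and chloro at this position.

From the compounds shown here alone, whether fluoro, iodo or an amine at this position would stand with compound 3 or with compound 4 remains open. Going by these compounds, this reading also rests on one pair, so whether the same swap gives a step of this size on another core is unknown.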